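The source may report more compounds than this note shows. Statements on the series, on what has been measured and on what is new or still open speak of the compounds shown alone.

Compound 1, with the structure `COC(=O)c1ccc(NC(=O)CSc2ncncc2-c2cccc3ccccc23)c(Br)c1`, is tested in an ADME assay on MT4 cells (Homo sapiens) for cytotoxicity, read by MTT assay (a lower number here means that less compound is tolerated, a higher number that more compound is tolerated), where compound 1 gives 168000 nM. Compound 2, with the structure `CCOC(=O)c1ccc(NC(=O)CSc2ncncc2-c2cccc3ccccc23)c(Br)c1`, shares its core and in this assay compound 2 gives 211000 nM. The change from compound 1 to compound 2 is methyl in place of hydrogen on a saturated chain carbon bound to an oxygen next to a carbonyl group, and it makes a 1.3-fold higher number from compound 1 to compound 2 (0.10 log units; within the scatter). Compound 3, with the structure `CCOC(=O)CNC(=O)c1ccc(NC(=O)CSc2ncncc2-c2cccc3ccccc23)c(Cl)c1`, carries a different core; how the two cores differ is not broken down here. In this assay compound 3 gives 105000 nM, and its values against compound 1 and compound 2 lie within the scatter of one another.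

Compound 4, with the structure `CCOC(=O)C(C)NC(=O)c1ccc(NC(=O)CSc2ncncc2-c2cccc3ccccc23)c(Cl)c1`, is not yet measured. It differs from compound 3 by methyl in place of hydrogen on a saturated chain carbon bound to an amide-type nitrogen and a carbonyl carbon. Within the data shown here, this is the same kind of change as the one between compound 1 and compound 2, but the surroundings differ: in the earlier pair the methyl enters on a saturated chain carbon bound to an oxygen next to a carbonyl group, whereas here it enters on a saturated chain carbon bound to an amide-type nitrogen and a carbonyl carbon. Because the earlier step, a 1.3-fold higher number from compound 1 to compound 2 (0.10 log units; within the scatter), stays within the scatter, the step from compound 3 to compound 4 in this assay is expected to be small as well, a 1.2-fold higher number from compound 3 to compound 4 (0.09 log units; within the scatter). Compound 4 is therefore estimated to give 130000 nM in this assay, with a range from 60000 nM to 280000 nM.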

Compound 4, half-maximal cytotoxic concentration: 35600 nM
Beside the measured number, compound 4's estimate is 3.7-fold (0.56 log units) above it, outside the stated range (below it).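

In this assay, the methyl that turns the (ethoxycarbonyl)methyl group of compound 3 into the 1-(ethoxycarbonyl)ethyl group of compound 4 gives a 2.9-fold lower number from compound 3 to compound 4 (0.47 log units; beyond the scatter), a modest step, and it does not match the step seen earlier on the other core: the same change on two cores in this assay, a 1.3-fold higher number (0.10 log units; within the scatter) from compound 1 to compound 2 and a 2.9-fold lower number (0.47 log units; beyond the scatter) from compound 3 to compound 4, 3.7-fold (0.57 log units) apart, beyond the scatter of two such steps

This shows that, in this series, the near-silent result of adding a methyl on one core cannot simply be carried to another, since on the core of compound 3 less of the compound is tolerated once the methyl is in place. It does not show what sets the two steps apart, as the pairs differ both in their cores and in the surroundings of the methyl, one on a saturated chain carbon bound to an oxygen next to a carbonyl group and the other on a saturated chain carbon bound to an amide-type nitrogen and a carbonyl carbon, and each kind of change rests on a single pair.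

The compounds shown leave open whether a longer chain at that same carbon would lower the number further or leave it where it stands. They also leave open whether the step from compound 3 to compound 4 would hold if a carboxylic acid took the place of the ethyl ester.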